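The compounds below may be only part of what the source reports. "The series", "measured", "known", "first", "only" and "open" are said of these compounds alone.

In a functional assay on HCT-116 cells (Homo sapiens) for inhibition, read by colorimetric assay, with a stated time of 3 days (a lower number here means a stronger inhibitor, a higher number a weaker inhibitor), two compounds have been measured that share one core and differ in the group on an amide-type nitrogen. Compound 1 (`COc1ccccc1NC(=O)CCCCCCNC(=O)C(O)(O)C(F)(F)F`) gives 10100 nM. Compound 2 (`O=C(CCCCCCNC(=O)C(O)(O)C(F)(F)F)Nc1c(F)cc(F)cc1F`) gives 22200 nM, the higher of the two numbers, which makes compound 2 the weaker inhibitor of this pair.

Compound 3 (`O=C(CCCCCCNC(=O)C(O)(O)C(F)(F)F)Nc1cccc(Br)c1`) keeps the shared core and changes the group at that same place: 3-bromophenyl in place of 2,4,6-trifluorophenyl on an amide-type nitrogen. In short, 3-bromophenyl comes in place of 2,4,6-trifluorophenyl.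

Among the compounds with values here, the only guide is one measured step, a 2.2-fold higher number from compound 1 to compound 2 (0.34 log units; beyond the scatter), which is modest. Neither measured compound carries a 3-bromophenyl, so this is thin evidence. It suggests that swapping the group here moves the number only a little. Since compound 2 stands at the top of the two numbers, a small move toward a lower number is expected in this assay, perhaps no larger than the scatter. The expected step is a 1.7-fold lower number from compound 2 to compound 3 (0.23 log units; within the scatter). For compound 3 the estimated value is 13000 nM, with an expected range from 5500 nM to 28000 nM.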

Compound 3, half-maximal inhibitory concentration: 3060 nM
Compound 3: the middle estimate sits 4.2-fold (0.63 log units) above what was measured, and the stated range ends above it.
By their numbers in this assay, from the lowest: compound 3; then compound 1; then compound 2.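

In this assay, the group on the amide-type nitrogen turns out to matter more than the first pair suggested: 3-bromophenyl in place of 2,4,6-trifluorophenyl gives a 7.3-fold lower number from compound 2 to compound 3 (0.86 log units; beyond the scatter), a larger step than a 2.2-fold higher number from compound 1 to compound 2 (0.34 log units; beyond the scatter). The 3-bromophenyl group also compares well with the 2-methoxyphenyl group, with a 3.3-fold lower number from compound 1 to compound 3 (0.52 log units; beyond the scatter), which makes compound 3 the strongest inhibitor of the three, since its steps to both others lie beyond the scatter. Both groups in the new step are six-membered aromatic rings of carbon only, with no hydrogen-bond donors or acceptors, so the counts do not separate them beyond the fluorine and bromine they carry, and no measurement at hand gives a reason for the step.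

From the compounds shown here alone, what a plain phenyl ring or a chlorophenyl would give at this nitrogen stays open, so three compounds cannot show whether bromine itself matters or any similar ring would do as well. Also open, going by these compounds, is how a group with no aromatic ring, such as a simple alkyl chain, or a ring carrying an amine or a carboxylic acid, would behave here.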